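The compounds below may be only part of what the source reports. "The series", "measured", "known", "first", "only" and "open" are said of these compounds alone.

Measured in a functional assay on PC-3 cells (Homo sapiens) for inhibition, with a stated time of 72 h; a higher number here means a weaker inhibitor, a lower number a stronger inhibitor:
Compound 1 `CO[C@H]1CC[C@H](CN2C(=O)CNc3ncc(-c4ccc(-c5nc[nH]n5)nc4C)nc32)CC1`: 142 nM
Compound 2 `Cc1nc(-c2nc[nH]n2)ccc1-c1cnc2c(n1)N([C@H]1CC[C@@H](O)CC1)C(=O)CN2`: 37 nM
Compound 3 `Cc1nc(-c2nc[nH]n2)ccc1-c1cnc2c(n1)N(C(C)C)C(=O)CN2`: 149 nM

In this assay, compound 3 cannot be told apart from compound 1, with a 1.0-fold higher number from compound 1 to compound 3 (0.02 log units; within the scatter). Only compound 2 stands apart, with a 3.8-fold lower number from compound 1 to compound 2 (0.58 log units; beyond the scatter) and a 4.0-fold higher number from compound 2 to compound 3 (0.60 log units; beyond the scatter).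

The next compound, compound 4 `CO[C@H]1CC[C@H](N2C(=O)CNc3ncc(-c4ccc(-c5nc[nH]n5)nc4C)nc32)CC1`, is reached from compound 3 by placing 4-methoxycyclohexyl in place of isopropyl on an amide-type nitrogen in a ring.

Among the compounds with values here, two measured steps bear on this change. The closer one is a 4.0-fold higher number from compound 2 to compound 3 (0.60 log units; beyond the scatter), since compound 2 also carries a 4-substituted cyclohexyl on that nitrogen, though with hydroxy rather than methoxy. Against it stands a 1.0-fold higher number from compound 1 to compound 3 (0.02 log units; within the scatter), which shows that the methoxy-bearing (4-methoxycyclohexyl)methyl of compound 1 offers no gain over isopropyl. Within the data shown here, no measured pair compares hydroxy with methoxy directly on this cyclohexyl. A modest step towards a lower number is therefore expected in this assay, smaller than the gap separating compound 2 from compound 3.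

The expected step is a 2.0-fold lower number from compound 3 to compound 4 (0.30 log units; within the scatter). For compound 4 the estimated value is 75 nM, within an expected range of 28 nM to 190 nM.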

Compound 4, half-maximal inhibitory concentration: 38 nM
For compound 4 the middle estimate is 2.0-fold (0.30 log units) above the measured one, and the stated range covers the measured number.
By their numbers in this assay, from the lowest: compounds 2 and 4 (each within the scatter of the next); then compounds 1 and 3 (each within the scatter of the next).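

In this assay, the gain over isopropyl is now seen with a second 4-substituted cyclohexyl on the amide-type nitrogen in a ring (a 3.9-fold lower number from compound 3 to compound 4 (0.59 log units; beyond the scatter)), so among the compounds shown it is not confined to the 4-hydroxycyclohexyl of compound 2. Within the data shown here, the direct comparison of the two cyclohexyl groups, which the earlier compounds lacked, shows no difference that can be told from the scatter (a 1.0-fold higher number from compound 2 to compound 4 (0.01 log units; within the scatter)), so hydroxy and methoxy cannot be separated at this position in these compounds. The comparison with (4-methoxycyclohexyl)methyl (a 3.7-fold lower number from compound 1 to compound 4 (0.57 log units; beyond the scatter)) shows that a methoxy group alone does not bring the gain: with methoxy present in both compounds, the number is lower where the cyclohexyl sits directly on the nitrogen.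

Nothing among the data shown explains any of these steps. Going by these compounds, it remains open whether an amine or a carboxylic acid on the cyclohexyl would keep the number of compound 4, whether a longer chain in place of methoxy would do so, and whether the opposite arrangement of the two stereocentres in 4-methoxycyclohexyl would matter.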